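Swapping a Carboxy Group for a (Dimethylamino)methyl Group on Two Cores

A few compounds are considered here, and "the series" means these few. Any claim that something is new, unique, unknown or untested is made for them only; others in the source may bear on it.

Of the compounds shown here, three have been tested in an assay on NK92 cells for inhibition of interleukin-2 (Homo sapiens), read by AlphaScreen, with stated times of 30 min and 1 h; a higher number here means a weaker inhibitor, a lower number a stronger inhibitor. Compound 1 `CN(C)CCCn1c(Cc2nn(C)c(=O)c3ccccc23)nnc1SCCCCCCCC(=O)Nc1ccc(Cl)cc1Cl` reaches only the limit of the assay, giving > 30000 nM. Where compound 1 carries a (dimethylamino)methyl group, compound 2 `Cn1nc(Cc2nnc(SCCCCCCCC(=O)Nc3ccc(Cl)cc3Cl)n2CCC(=O)O)c2ccccc2c1=O` carries a carboxy group and gives 14300 nM. The step between them is an at least 2.0-fold higher number from compound 2 to compound 1 (0.32 log units; beyond the scatter), with the difference ((dimethylamino)methyl in place of carboxy on a saturated chain carbon, two bonds along the chain from an aromatic nitrogen). Compound 3 `Cn1c(Cc2nn(CCC(=O)O)c(=O)c3ccccc23)nnc1SCC(=O)Nc1ccc(Cl)cc1Cl` also sits at the limit of the assay, giving > 30000 nM. Compound 2 and compound 3 share the same two ring systems but differ in where the side chains are attached; the difference between the two cores is not broken down here.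

Compound 4 `CN(C)CCCn1nc(Cc2nnc(SCC(=O)Nc3ccc(Cl)cc3Cl)n2C)c2ccccc2c1=O` has not yet been tested. It stands to compound 3 as compound 1 stands to compound 2: the difference is (dimethylamino)methyl in place of carboxy on a saturated chain carbon, two bonds along the chain from an aromatic nitrogen, the same kind of change in the same kind of place, but made on the other core. For the measured compounds named here, the single measured example of this change points toward weaker inhibition. Because compound 3 already gives > 30000 nM, and because the matched pair showed an at least 2.0-fold higher number from compound 2 to compound 1 (0.32 log units; beyond the scatter) against a limit at which two of three values sit (the limit of > 30000 nM in this assay, at which 2 of the 3 values shown sit), compound 4 is expected to land at or beyond that limit as well. The expected step is a step that the limit leaves unreadable from compound 3 to compound 4, and the expected value for compound 4 is 60000 nM, within a range from 25000 nM to 250000 nM.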

Compound 4, half-maximal inhibitory concentration: > 30000 nM
Compound 4: only a limit was reported; the forecaster's own chance of this, stated with the estimate: 80%; the middle value lies beyond the limit too.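

In this assay compound 4 gives > 30000 nM, a limit of the assay and not a number, and compound 3 stands at that same limit. No size can be read for the step from compound 3 to compound 4, because both sit at the limit: the limit of > 30000 nM in this assay, at which 3 of the 4 values shown sit.

Still open, as far as these compounds go, is whether swapping carboxy for (dimethylamino)methyl changes inhibition on the core of compound 3 as it does on the core of compound 2.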